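Cytotoxicity of benzoxazole sulfonamides: from hydroxy to fluoro

This account rests on a few compounds, and the source may have more. Where it says the series, first, only, none or still open, it means among the compounds named here.

Measured so far in an ADME assay on HEK293 cells (Homo sapiens) for cytotoxicity, read by resazurin assay, with a stated time of 48 h; on this read-out higher numbers stand for lower toxicity in this test and lower numbers for higher toxicity in this test:
compound 1 `O=S(=O)(Nc1ccc2oc(-c3ccccc3)nc2c1)c1ccccc1O` gives 33000 nM
compound 2 `O=S(=O)(Nc1ccc2oc(-c3ccccc3)nc2c1)c1ccccc1Cl` gives 73000 nM
compound 3 `O=S(=O)(Nc1ccc2oc(-c3ccccc3)nc2c1)c1cccc(O)c1` gives > 100000 nM

The value of compound 3 is a limit of the assay and not a number; it sits at the limit of > 100000 nM in this assay, at which 1 of the 3 values shown sits, so compound 3 stands at the top of the shown range. Compound 4 `O=S(=O)(Nc1ccc2oc(-c3ccccc3)nc2c1)c1ccccc1F` differs from compound 3 in one place: 2-fluorophenyl in place of 3-hydroxyphenyl on a sulfonyl sulfur. Among the compounds with values here, two measured steps bear on this move. The step of an at least 3.0-fold higher number from compound 1 to compound 3 (0.48 log units; beyond the scatter) and the step of an at least 1.3-fold higher number from compound 2 to compound 3 (0.13 log units; that floor lies within the scatter) both run toward compound 3, and the second of them has a floor inside the scatter. Compound 2, which also carries a halogen in the same position of the ring on the sulfonyl sulfur, gives 73000 nM. Compound 4 is therefore expected to return to about the level of compound 2, a small downward step of an at least 1.4-fold lower number from compound 3 to compound 4 (0.15 log units; that floor lies within the scatter) from compound 3, though one that may still be hidden by the limit. The estimate for compound 4 is 70000 nM, with a range from 35000 nM to 140000 nM.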

Compound 4, half-maximal cytotoxic concentration: 72000 nM
Beside the measured number, compound 4's estimate is 1.0-fold (0.01 log units) below it; the measured number falls inside the stated range.
By their numbers in this assay, from the lowest: compound 1; then compounds 4 and 2 (each within the scatter of the next). At a limit, above all of these: compound 3.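

In this assay, chloro and fluoro on this aromatic carbon cannot be told apart, a 1.0-fold lower number from compound 2 to compound 4 (0.01 log units; within the scatter), while replacing hydroxy with fluoro gives a 2.2-fold higher number from compound 1 to compound 4 (0.34 log units; beyond the scatter), the same size as the step with chloro, a 2.2-fold higher number from compound 1 to compound 2 (0.34 log units; beyond the scatter). Compound 3 stands at a limit of the assay and not at a number: the limit of > 100000 nM in this assay, at which 1 of the 4 values shown sits. The change from 3-hydroxyphenyl to 2-fluorophenyl on the sulfonyl sulfur can be read only as a floor, an at least 1.3-fold lower number from compound 3 to compound 4 (0.14 log units; that floor lies within the scatter).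

The compounds shown leave open whether 3-fluorophenyl or 3-chlorophenyl on the sulfonyl sulfur would stand with compound 4 or with compound 3 in this assay. They also leave open how an amine, a methoxy group or a carboxylic acid in place of the fluoro of compound 4 would read.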